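Swapping a furan for a pyridine on a semicarbazone analogue

The source may hold more compounds than are shown below. What is called first, only, known or untested is meant among the compounds shown, and "the series" means these compounds.

Measured so far:
- compound 1, `CC(=O)c1ccc2c(c1)nc(-c1ccoc1)n2C1CCCCC1`: 80000 nM
- compound 2, `CC(=O)c1ccc2c(c1)nc(-c1ccccn1)n2C1CCCCC1`: > 90000 nM
- compound 3, `C/C(=N\NC(N)=O)c1ccc2c(c1)nc(-c1ccoc1)n2C1CCCCC1`: "not determined" (no result reported)

Compound 1 `CC(=O)c1ccc2c(c1)nc(-c1ccoc1)n2C1CCCCC1` was tested in an ADME assay on Vero cells (Chlorocebus sabaeus) for cytotoxicity, read by MTT assay, with a stated time of 96 h (on this read-out lower numbers stand for higher toxicity in this test and higher numbers for lower toxicity in this test), and gave 80000 nM. Compound 2 `CC(=O)c1ccc2c(c1)nc(-c1ccccn1)n2C1CCCCC1` differs from it by pyridin-2-yl in place of furan-3-yl on an aromatic carbon. In this assay compound 2 reached only a limit of the assay, > 90000 nM, and not a number. The step of an at least 1.1-fold higher number from compound 1 to compound 2 (0.05 log units; that floor lies within the scatter) therefore has a floor only; the floor comes from the limit of > 90000 nM in this assay, at which 1 of the 3 values shown sits. Compound 3 `C/C(=N\NC(N)=O)c1ccc2c(c1)nc(-c1ccoc1)n2C1CCCCC1` carries a different core, and the difference from compound 1 is a group of 7 heavy atoms (3 carbon, 3 nitrogen, 1 oxygen; no ring) in place of a group of 3 heavy atoms (2 carbon, 1 oxygen; no ring), on an aromatic carbon. For compound 3 the entry in this assay reads "not determined" (no result reported), so no result was reported.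

Compound 4 `C/C(=N\NC(N)=O)c1ccc2c(c1)nc(-c1ccccn1)n2C1CCCCC1` has not yet been measured. It differs from compound 3 by pyridin-2-yl in place of furan-3-yl on an aromatic carbon, and the place of the change is described in the same words as for the step from compound 1 to compound 2, so this is the same change made on the other core. Its effect on the first core is known only as a floor through an at least 1.1-fold higher number from compound 1 to compound 2 (0.05 log units; that floor lies within the scatter), and nothing is known of compound 3 itself in this assay, so the expectation for compound 4 rests on the two measured compounds alone, both of which sit at low toxicity. Compound 4 is expected to give about 90000 nM in this assay, estimated to lie between 40000 nM and 200000 nM, with a fair chance that only a limit is reported.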

Compound 4, half-maximal cytotoxic concentration: > 100000 nM
Compound 4: a limit, no number; the forecaster's own chance of this, stated with the estimate: 60%; middle value at least 1.1-fold (0.04 log units) away from the limit.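

In this assay compound 4 gives > 100000 nM, which is a limit of the assay and not a number. Going by these compounds alone, compound 2 also stands at a limit and compound 3 has no reported result, so no step from either one to compound 4 can be read. The compounds shown leave open whether pyridin-2-yl in place of furan-3-yl changes this read-out on either core.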